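The source may report more compounds than this note shows. Statements on the series, on what has been measured and on what is new or still open speak of the compounds shown alone.

In a functional assay on A549 cells (Homo sapiens) for cytotoxicity, read by MTT assay, with a stated time of 72 h (a higher number here means a weaker inhibitor, a lower number a stronger inhibitor), compound 3 `COc1ccc(/C=C/C(=O)Nc2cc3c(Nc4ccc(F)c(Cl)c4)ncnc3cc2O[C@H]2CCOC2)c(OC)c1` gives 9350 nM. This is the lowest of the two numbers recorded there. Its nearest neighbour is compound 1 `COc1ccc(/C=C/C(=O)Nc2cc3c(Nc4ccc(F)c(Cl)c4)ncnc3cc2OC)c(OC)c1`, which gives 33300 nM in this assay; the step of a 3.6-fold lower number from compound 1 to compound 3 (0.55 log units; beyond the scatter) is the only one measured. Compound 2 `COc1cc(/C=C/C(=O)Nc2cc3c(Nc4ccc(F)c(Cl)c4)ncnc3cc2OC)cc(OC)c1` is recorded as "not active" (no number reported) in this assay, so no number is available for it. Compound 4 `COc1ccc(/C=C/C(=O)Nc2cc3c(Nc4ccc(F)c(Cl)c4)ncnc3cc2O[C@H]2CCOC2)cc1` differs from compound 3 by hydrogen in place of methoxy on an aromatic carbon. Going by the values given here, no measured step touches this part of the molecule, and the absence of a number for compound 2 gives no size for changes on this ring. Compound 4 is therefore expected to stay close to compound 3, with a 1.6-fold higher number from compound 3 to compound 4 (0.21 log units; within the scatter) toward a somewhat higher number. The estimate for compound 4 is 15000 nM, within 5000 nM to 50000 nM.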

Compound 4, half-maximal inhibitory concentration: 3050 nM
For compound 4 the middle estimate is 4.9-fold (0.69 log units) above the measured one; the measured number lies below the stated range.
By their numbers in this assay, from the lowest: compound 4; then compound 3; then compound 1.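

In this assay, going by these compounds alone, going from 2,4-dimethoxyphenyl to 4-methoxyphenyl gives a 3.1-fold lower number from compound 3 to compound 4 (0.49 log units; beyond the scatter) and so puts the first size on a change at this ring position. At this place in the series, the methoxy group is not required for activity, and hydrogen gives the lower number. No measurement shown here offers an explanation for this step.

From the compounds shown here alone, how a fluorine atom or an ethoxy group would compare with hydrogen at this place remains open. Going by these compounds, it is also open whether removing this methoxy group would give a similar step in compound 1.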